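From ethyl to tert-butyl: will cell tolerance hold?

The source may hold more compounds than are shown below. What is called first, only, known or untested is meant among the compounds shown, and "the series" means these compounds.

Compound 1 `COc1ccc(C(=O)NNc2c(Br)cccc2Br)cc1`: > 100000 nM, a limit
Compound 2 `CCc1ccc(C(=O)NNc2c(Br)cccc2Br)cc1`: > 100000 nM, a limit

In a toxicity assay on MDCK cells (Canis lupus familiaris) for cytotoxicity, read by CCK-8 assay, with a stated time of 48 h (a lower number here means that less compound is tolerated, a higher number that more compound is tolerated), compound 2 stands at > 100000 nM, which is a limit and not an exact number. Both measured compounds share it: the limit of > 100000 nM in this assay, at which 2 of the 2 values shown sit. The next change, (tert-butyl in place of ethyl on an aromatic carbon), is tert-butyl in place of ethyl on an aromatic carbon and gives compound 3 `CC(C)(C)c1ccc(C(=O)NNc2c(Br)cccc2Br)cc1`. For the measured compounds named here, the only measured step is a step that the two limits leave unreadable from compound 1 to compound 2, so it offers no size and no direction to build on. No shift beyond the scatter is therefore expected, and the estimated step is a number no higher from compound 2 to compound 3 (the limit leaves the size open). The estimate for compound 3 is 100000 nM, with an expected range from 40000 nM to 200000 nM.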

Compound 3, half-maximal cytotoxic concentration: > 100000 nM
Compound 3: only a limit was reported (the forecaster's own chance of this, stated with the estimate: 80%); the middle value lies on the limit itself.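

For the compounds shown here, compound 3 also sits at a limit, so no step among compound 1, compound 2 and compound 3 can be read: the limit of > 100000 nM in this assay, at which 3 of the 3 values shown sit. The compounds shown leave open whether methoxy, ethyl and tert-butyl differ at all in this assay.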